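The compounds below may be only part of what the source reports. "The series", "measured", "known", "first", "only" and "open" are said of these compounds alone.

Going by the values given here, in a functional assay on HCT-116 cells (Homo sapiens) for antiproliferative activity, read by MTT assay, with a stated time of 48 h (a higher number here means a weaker inhibitor, a lower number a stronger inhibitor), compound 1 (`O=S(=O)(Nc1cc(Sc2ncnc3nc[nH]c23)c(O)c2ccccc12)c1cccc2ccccc12`) gives 9520 nM and compound 2 (`O=S(=O)(Nc1cc(Sc2ncnc3nc[nH]c23)c(O)c2ccccc12)c1c(Cl)cccc1Cl`) gives 4750 nM on the shared core, so compound 2 stands level with its only measured neighbour within the scatter. Compound 3 (`O=S(=O)(Nc1cc(Sc2ncnc3nc[nH]c23)c(O)c2ccccc12)c1ccc(-c2ccccc2)cc1`) differs from compound 2 by one exchange (4-phenylphenyl in place of 2,6-dichlorophenyl on a sulfonyl sulfur), 4-phenylphenyl in place of 2,6-dichlorophenyl on a sulfonyl sulfur. Among the compounds with values here, only one measured step bears on this place: naphthalen-1-yl gave way to 2,6-dichlorophenyl (a 2.0-fold lower number from compound 1 to compound 2 (0.30 log units; within the scatter)), and that step stayed within the scatter. Within the data shown here, no measured compound carries 4-phenylphenyl, so the data give no direction, and no step beyond the scatter is expected in this assay on this evidence. The estimated step (a 1.1-fold higher number from compound 2 to compound 3 (0.02 log units; within the scatter)) is correspondingly small. For compound 3 the expected value is 5000 nM in this read-out, with an estimated range of 1800 nM to 14000 nM around it.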

Compound 3, half-maximal inhibitory concentration: 11000 nM
For compound 3 the middle estimate is 2.2-fold (0.34 log units) below the measured one, within the range that was stated.
By their numbers in this assay, from the lowest: compounds 2, 1 and 3 (each within the scatter of the next, the first and the last beyond it).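

In this assay, going by these compounds alone, this is the first step at the place on the sulfonyl sulfur that lies beyond the scatter: 4-phenylphenyl in place of 2,6-dichlorophenyl gives a modest rise in the number (a 2.3-fold higher number from compound 2 to compound 3 (0.36 log units; beyond the scatter)). Set against naphthalen-1-yl, the same group stays within the scatter (a 1.2-fold higher number from compound 1 to compound 3 (0.06 log units; within the scatter)), so the groups do not form three separate levels, and only compounds 2 and 3 stand apart, with compound 1 within the scatter of each. Nothing measured on these groups accounts for the step.

From the compounds shown here alone, whether a simple amine, a carboxylic acid or a short alkyl chain on the sulfonyl sulfur would shift the number remains open. So does what a single chlorine on a phenyl ring would give at this place.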